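The source may report more compounds than this note shows. Statements on the series, on what has been measured and on what is new or still open speak of the compounds shown alone.

Compound 1 `Cc1cccc(/C=N/Nc2ncc3c(n2)n(C2CCCC2)c(=O)c(=O)n3C)c1` gives 34500 nM in a functional assay on A549 cells (Homo sapiens) for antiproliferative activity, read by MTT assay (a higher number here means a weaker inhibitor, a lower number a stronger inhibitor), the second highest of the three numbers recorded. Compound 2 `Cn1c(=O)c(=O)n(C2CCCC2)c2nc(N/N=C/c3ccc(F)c(Cl)c3)ncc21` gives 9410 nM in this assay, and compound 3 `Cn1c(=O)c(=O)n(C2CCCC2)c2nc(N/N=C/c3ccc(S(C)(=O)=O)cc3)ncc21` gives 84500 nM. Compound 4 `Cn1c(=O)c(=O)n(C2CCCC2)c2nc(N/N=C/c3cccs3)ncc21` differs from compound 1 at one place: thiophen-2-yl in place of 3-methylphenyl on a carbon with a double bond to nitrogen. Two measured steps start from compound 1: a 3.7-fold lower number from compound 1 to compound 2 (0.56 log units; beyond the scatter), and a 2.4-fold higher number from compound 1 to compound 3 (0.39 log units; beyond the scatter). Both exchange the 3-methylphenyl for another six-membered aromatic ring of carbon only, and neither involves a five-membered aromatic ring with one hetero atom, so the data give no direction for this change. The step expected in this assay is therefore small, a 1.2-fold higher number from compound 1 to compound 4 (0.06 log units; within the scatter), likely within the scatter. Compound 4 is estimated at 40000 nM, with a range from 12000 nM to 130000 nM.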

Compound 4, half-maximal inhibitory concentration: > 100000 nM
Compound 4 ended at the assay's limit (the forecaster's own chance of this, stated with the estimate: 10%); at least 2.5-fold (0.39 log units) between middle value and limit.
By their numbers in this assay, from the lowest: compound 2; then compound 1; then compound 3. At a limit, above all of these: compound 4.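

In this assay compound 4 gives only a limit, > 100000 nM and not a number. Thiophen-2-yl on this carbon thus does worse than two of the six-membered aromatic rings, with an at least 2.8-fold higher number from compound 1 to compound 4 (0.46 log units; beyond the scatter) and an at least 10-fold higher number from compound 2 to compound 4 (1.02 log units; beyond the scatter) as the readable steps. Against 4-(methylsulfonyl)phenyl, an at least 1.1-fold higher number from compound 3 to compound 4 (0.07 log units; that floor lies within the scatter) does not separate the two groups. The compounds shown leave open whether the loss follows the sulfur or the five-membered ring, and whether furan-2-yl, thiophen-3-yl or pyridin-3-yl at this place would give a number in this assay instead of a limit.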